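Pyridin-2-yl replaces 3-methylphenyl in compound 4

The source may report more compounds than this note shows. Statements on the series, on what has been measured and on what is new or still open speak of the compounds shown alone.

In a functional assay on HeLa cells (Homo sapiens) for cytotoxicity, read by ELISA, with a stated time of 4 days (on this read-out higher numbers stand for weaker inhibition and lower numbers for stronger inhibition), compound 1 `Cc1ccsc1-c1cc(-c2ccco2)cc(-c2ccc(Cl)cc2)n1` gives 24500 nM, compound 2 `Clc1ccc(-c2cc(-c3ccco3)cc(-c3ccc(Cl)s3)n2)cc1` gives 17000 nM and compound 3 `Cc1cccc(-c2cc(-c3ccoc3)cc(-c3ccc(Cl)s3)n2)c1` gives 23600 nM. Compound 3 therefore sits level with the other two, all within the usual scatter of this kind of measurement. Compound 4 `Clc1ccc(-c2cc(-c3ccoc3)cc(-c3ccccn3)n2)s1` has pyridin-2-yl in place of 3-methylphenyl on an aromatic carbon. Among the compounds with values here, no measured step makes this exact change. The nearest one, a 1.4-fold lower number from compound 1 to compound 2 (0.16 log units; within the scatter), swaps a different group and stays within the scatter, so it offers only weak guidance, and no shift beyond the scatter is expected. In this assay the estimated value for compound 4 is 17000 nM, with an expected range of 6000 nM to 45000 nM. That would be an expected 1.4-fold lower number from compound 3 to compound 4 (0.14 log units; within the scatter).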

Compound 4, half-maximal inhibitory concentration: 21600 nM
Compound 4: middle estimate off by 1.3-fold (0.10 log units), on the low side, within the range that was stated.
By their numbers in this assay, from the lowest: compounds 2, 4, 3 and 1 (each within the scatter of the next).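

Placing pyridin-2-yl, with its ring nitrogen, where 3-methylphenyl stood leaves the reading in this assay level: a 1.1-fold lower number from compound 3 to compound 4 (0.04 log units; within the scatter). At this position, next to the ring nitrogen of the core, a carbon-only aromatic ring and one with a hetero atom therefore read alike, at least in this single pair. No other data explain this result.

Still open, from the compounds shown here alone, is whether a non-aromatic group at this position, such as an amine or a carboxylic acid, would shift the number beyond the scatter. Also open is whether any of these compounds has a specific effect on the cells.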